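Compound 3 and a value near the limit

The compounds below may be only part of what the source reports. "The series", "measured", "known", "first", "only" and "open" are said of these compounds alone.

Measured in an ADME assay on MCF7-DOX cells (Homo sapiens) for cytotoxicity, read by MTT assay, with a stated time of 48 h; a lower number here means a stronger inhibitor, a higher number a weaker inhibitor:

- Compound 1 `COc1cc(O)c(C(=O)/C=C/c2cccc(N3CCNCC3)c2)c(OC)c1`: 99200 nM
- Compound 2 `CCc1c(OC)cc(OC)c(C(=O)/C=C/c2cccc(N3CCNCC3)c2)c1O`: > 100000 nM (a limit)

Among the compounds with values here, compound 1 gives 99200 nM, the only true number in this small set. Compound 2 gives > 100000 nM, which is a limit and not a number. Compound 1 therefore lies close to the limit of > 100000 nM in this assay, at which 1 of the 2 values shown sits.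

Compound 3 `COc1cc(O)c(C(=O)/C=C/c2cccc(N3CCN(C(=O)OC(C)(C)C)CC3)c2)c(OC)c1` differs from compound 1 by tert-butoxycarbonyl in place of hydrogen on an amine nitrogen in a ring. Within the data shown here, the one measured step, a number no lower from compound 1 to compound 2 (the limit leaves the size open), is an ethyl change on an aromatic carbon, at a different place, and its size stays open. It therefore gives no size to carry over.

With compound 1 at 99200 nM, little room remains for a weaker number in this assay, so any readable change is expected towards stronger inhibition. The expected step is a 1.5-fold lower number from compound 1 to compound 3 (0.18 log units; within the scatter). Compound 3 is estimated at 65000 nM, within an expected range of 20000 nM to 100000 nM.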

Compound 3, half-maximal inhibitory concentration: 56700 nM
Compound 3: middle estimate off by 1.1-fold (0.06 log units), on the high side; the measured number falls inside the stated range.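

In this assay, within the data shown here, tert-butoxycarbonyl in place of hydrogen on the amine nitrogen gives a 1.7-fold lower number from compound 1 to compound 3 (0.24 log units; within the scatter), the first step in this set whose size can be read and the first at this nitrogen. A group of this size on the ring nitrogen therefore leaves the number within the scatter, so this change shows no readable gain or loss, whereas the earlier pair offered only a change on an aromatic carbon. Compound 2 stands at a limit and not a number, so its step cannot be read: the limit of > 100000 nM in this assay, at which 1 of the 3 values shown sits.

The compounds shown leave open whether a different group on this nitrogen, such as a methyl, an acetyl or a longer chain ending in an amine, would move the number beyond the scatter. They also leave open whether any such group would behave alike on a core carrying the ethyl of compound 2.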